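The source may report more compounds than this note shows. Statements on the series, on what has been measured and on what is new or still open speak of the compounds shown alone.

Compound 1 `COCCOc1cc(/C=C/c2ccc3ccccc3c2)ccc1OC`: 2990 nM
Compound 2 `COCCOc1cc(/C=C\c2ccc3ccccc3c2)ccc1OC`: 2990 nM
Compound 3 `COc1cccc(/C=C\c2ccc3ccccc3c2)c1`: 1920 nM

In a functional assay on A549 cells (Homo sapiens) for inhibition (on this read-out higher numbers stand for weaker inhibition and lower numbers for stronger inhibition), compound 1 stands level with compound 2, and compound 3 lies within the scatter of both. Compound 4 `CCN(CC)c1cc(/C=C/c2ccc3ccccc3c2)ccc1OC` departs from compound 1 by one change: diethylamino in place of 2-methoxyethoxy on an aromatic carbon. It carries diethylamino in place of 2-methoxyethoxy on an aromatic carbon, ortho to a methoxy group. For the measured compounds named here, the only measured step shows no change at the digits printed from compound 1 to compound 2 (within the scatter), and it bears on this change only weakly, given (the fact that compounds 1 and 2 differ only in the configuration as drawn). Going by the values given here, no measured step touches the 2-methoxyethoxy group itself, so no step beyond the scatter is expected in this assay, in either direction. The expected step runs a 1.2-fold higher number from compound 1 to compound 4 (0.07 log units; within the scatter). For compound 4 the estimate is 3500 nM, with an expected range of 1200 nM to 10000 nM.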

Compound 4, half-maximal inhibitory concentration: > 5000 nM
Compound 4: only a limit was reported; the forecaster's own chance of this, stated with the estimate: 15%; middle value at least 1.4-fold (0.15 log units) from the limit.
By their numbers in this assay, from the lowest: compounds 3, 1 and 2 (each within the scatter of the next). At a limit, above all of these: compound 4.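

For the compounds shown here, compound 4 gives the first measured change at this position, on an aromatic carbon ortho to a methoxy group, where diethylamino replaces 2-methoxyethoxy. In this assay compound 4 reaches only a limit, > 5000 nM. The step reads an at least 1.6-fold higher number from compound 1 to compound 4 (0.22 log units; that floor lies within the scatter), so this swap brings no stronger inhibition, though its floor does not establish a real loss.

From the compounds shown here alone, how far the step truly runs stays open. Also open, going by these compounds, is how a smaller amine such as dimethylamino, a morpholine ring or a plain hydroxyl would read at this position.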